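The compounds below may be only part of what the source reports. "The series", "measured", "known", "first", "only" and "open" are said of these compounds alone.

Compound 1, `COc1ccc(-c2cnc(NC(=O)c3ccccc3F)n2C)cc1`, in a toxicity assay on THP-1 cells (Homo sapiens) for inhibition; a higher number here means that more compound is tolerated, a lower number that less compound is tolerated: > 100000 nM, a limit.
Compound 2, `COc1ccc(-c2cnc(NC(=O)C3CCCCC3)n2C)cc1`, in this assay: > 100000 nM, a limit.
Compound 3, `COc1ccc(-c2cnc(NC(=O)c3ccccn3)n2C)cc1`, in this assay: > 100000 nM, a limit.

Compound 3 stands at the limit of this assay, with no number below it. The values shown all share (the limit of > 100000 nM in this assay, at which 3 of the 3 values shown sit). Compound 4 is `COc1ccc(-c2cnc(NC(=O)c3ccccc3OC)n2C)cc1`. The change is 2-methoxyphenyl in place of pyridin-2-yl on a carbonyl carbon. The steps that exchange the group on the carbonyl carbon, a step that the two limits leave unreadable from compound 1 to compound 3, a step that the two limits leave unreadable from compound 2 to compound 3 and a step that the two limits leave unreadable from compound 1 to compound 2, fall between limits, so their sizes cannot be read. Three such exchanges left the limit where it was, so no step beyond the scatter is expected in this assay in either direction. Compound 4 is therefore estimated at 100000 nM, within 30000 nM to 300000 nM, most likely reported again only as a limit. The expected step is a number no higher from compound 3 to compound 4 (the limit leaves the size open).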

Compound 4, half-maximal cytotoxic concentration: > 100000 nM
Compound 4 ended at the assay's limit (the forecaster's own chance of this, stated with the estimate: 85%); the middle value sits exactly at the limit.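

Going by these compounds alone, no step between compound 1, compound 2, compound 3 and compound 4 can be read in this assay because all of them stand at one limit: the limit of > 100000 nM in this assay, at which 4 of the 4 values shown sit. From the compounds shown here alone, how much of each compound the cells would tolerate beyond that limit, and whether the groups on the carbonyl carbon differ in this respect, remains open.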